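This account rests on a few compounds, and the source may have more. Where it says the series, first, only, none or still open, it means among the compounds named here.

Of the compounds shown here, three on the shared core have been read so far in an ADME assay (liver) for metabolic stability, with Liver microsome (Rattus norvegicus) as the target, using microsomes and NADPH, with a stated time of 30 min, tested at 1 uM; on this read-out lower numbers stand for slow clearance and higher numbers for fast clearance. Compound 1 `Nc1ccc(S(=O)(=O)N2CCN(c3ncc(C(O)(C(F)(F)F)C(F)(F)F)cc3C#CC3CC3)CC2)cn1` gives 67 mL.min-1.g-1, compound 2 `COCC#Cc1cc(C(O)(C(F)(F)F)C(F)(F)F)cnc1N1CCN(S(=O)(=O)c2ccc(N)nc2)CC1` gives 399 mL.min-1.g-1 and compound 3 `CC(C)(O)C#Cc1cc(C(O)(C(F)(F)F)C(F)(F)F)cnc1N1CCN(S(=O)(=O)c2ccc(N)nc2)CC1` gives 16 mL.min-1.g-1, the lowest of the three numbers. They differ only in the group on a triple-bonded carbon, and that single change moves the number a long way: a 6.0-fold higher number from compound 1 to compound 2 (0.77 log units; beyond the scatter), a 4.2-fold lower number from compound 1 to compound 3 (0.62 log units; beyond the scatter) and a 25-fold lower number from compound 2 to compound 3 (1.40 log units; beyond the scatter).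

Next is compound 4 `Nc1ccc(S(=O)(=O)N2CCN(c3ncc(C(O)(C(F)(F)F)C(F)(F)F)cc3C#CCCO)CC2)cn1`, which carries 2-hydroxyethyl in place of the 1-hydroxy-1-methylethyl of compound 3 on a triple-bonded carbon: 2-hydroxyethyl in place of 1-hydroxy-1-methylethyl on a triple-bonded carbon.

The steps into compound 3 bear on this change, but none of them swaps one hydroxy-bearing group for another, so the size cannot be read off directly. Compound 4 keeps a hydroxy group, which the methoxymethyl of compound 2 lacks, so a return of the whole of a 25-fold lower number from compound 2 to compound 3 (1.40 log units; beyond the scatter) is not expected. Compound 3 is also the lowest so far, which makes a move upward the likelier direction. A modest rise is therefore expected, with the estimated step being a 2.5-fold higher number from compound 3 to compound 4 (0.40 log units; beyond the scatter). In this assay the expected value for compound 4 is 40 mL.min-1.g-1, with an estimated range from 14 mL.min-1.g-1 to 120 mL.min-1.g-1.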

Compound 4, intrinsic clearance in microsomes: 68 mL.min-1.g-1
The estimate for compound 4 lay 1.7-fold (0.23 log units) below the measured number, and the stated range covers the measured number.
By their numbers in this assay, from the lowest: compound 3; then compounds 1 and 4 (each within the scatter of the next); then compound 2.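

In this assay, the swap of 2-hydroxyethyl for 1-hydroxy-1-methylethyl on the triple-bonded carbon gives a 4.3-fold higher number from compound 3 to compound 4 (0.63 log units; beyond the scatter), so two groups that both carry a hydroxy group can still read apart and a hydroxy group alone does not fix the number at this position. Hydroxymethyl in place of methoxy on the saturated chain carbon gives a 5.9-fold lower number from compound 2 to compound 4 (0.77 log units; beyond the scatter), showing that a change at the far end of the chain also moves the read-out, while 2-hydroxyethyl in place of cyclopropyl gives a 1.0-fold higher number from compound 1 to compound 4 (0.01 log units; within the scatter), so a hydroxy-bearing chain and a ring with no hydroxy group can land at the same level and compound 1 stands against any simple rule that a hydroxy group is needed for a moderate number. No measurement shown accounts for any of these steps.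

The compounds shown do not separate the effect of the two methyl groups of 1-hydroxy-1-methylethyl from that of where the hydroxy group sits on the chain. On these data alone, how an amine, a carboxylic acid or a longer hydroxy-bearing chain on the triple-bonded carbon would read also remains open.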